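Working notes: cytotoxicity read-out across a side-chain change

The compounds below may be only part of what the source reports. "The series", "measured", "known", "first", "only" and "open" are said of these compounds alone.

Measured so far:
- compound 1 `CN(CCC#N)C[C@H]1CN(c2ccc(-n3cc(-c4ccccn4)cn3)c(F)c2)C(=O)O1`: > 400 ug/mL
- compound 2 `COC(=O)CC1CCN(C[C@H]2CN(c3ccc(-n4cc(-c5ccccn5)cn4)c(F)c3)C(=O)O2)CC1`: 224 ug/mL

In an ADME assay on HEK293-A cells (Homo sapiens) for cytotoxicity, read by MTT assay, with a stated time of 48 h (on this read-out higher numbers stand for weaker inhibition and lower numbers for stronger inhibition), compound 2 gives 224 ug/mL, the only number shown for the series. For compound 1 the reading > 400 ug/mL is a limit of the assay rather than a number (the limit of > 400 ug/mL in this assay, at which 1 of the 2 values shown sits). For the measured compounds named here, the single measured step, an at least 1.7-fold lower number from compound 1 to compound 2 (0.25 log units; that floor lies within the scatter), therefore has a floor that lies within the scatter, so no direction is established at this position.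

Compound 3 `O=C1CCC(=O)N1C[C@H]1CN(c2ccc(-n3cc(-c4ccccn4)cn3)c(F)c2)C(=O)O1` differs from compound 2 by 2,5-dioxopyrrolidin-1-yl in place of 4-((methoxycarbonyl)methyl)piperidin-1-yl on a saturated chain carbon bound to a saturated ring carbon. Going by the values given here, no measured step involves the entering group; the only step at this position, from compound 1 to compound 2, is within scatter. For compound 3 the expected change is a 1.3-fold higher number from compound 2 to compound 3 (0.13 log units; within the scatter), nothing beyond the scatter. Compound 3 is estimated at 300 ug/mL, within 150 ug/mL to 600 ug/mL, with a real chance that only a limit is reported.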

Compound 3, half-maximal inhibitory concentration: > 400 ug/mL
Compound 3 ended at the assay's limit; the forecaster's own chance of this, stated with the estimate: 40%; middle value at least 1.3-fold (0.12 log units) away from the limit.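

In this assay compound 3 gives > 400 ug/mL and that reading is a limit of the assay, not a number. For the compounds shown here, on the saturated chain carbon bound to a saturated ring carbon, 2,5-dioxopyrrolidin-1-yl now joins (2-cyanoethyl)(methyl)amino at the limit, and 4-((methoxycarbonyl)methyl)piperidin-1-yl in compound 2 remains the only group with a number: the limit of > 400 ug/mL in this assay, at which 2 of the 3 values shown sit. The step of an at least 1.7-fold higher number from compound 2 to compound 3 (0.25 log units; that floor lies within the scatter) sets no direction at this position, and the step between compound 1 and compound 3 cannot be read with both at limits.

As far as these compounds go, whether 4-((methoxycarbonyl)methyl)piperidin-1-yl truly differs from the other two groups stays open. Also open, from the compounds shown here alone, is how a carboxylic acid or a primary amine on the same chain carbon would read, and whether either would give a number clear of the limit.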